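The source may report more compounds than this note shows. Statements on the series, on what has been measured and on what is new or still open speak of the compounds shown alone.

Compound 1, with structure `Cc1ccc(NC(=O)Nc2cccc(CNc3nccnc3Cl)c2)cc1`, is one of three compounds tested in a functional assay on MGC-803 cells (Homo sapiens) for antiproliferative activity, read by MTT assay, with a stated time of 48 h (a lower number here means a stronger inhibitor, a higher number a weaker inhibitor), where compound 1 gives 11900 nM. This is the highest of the three numbers. Compound 2, with structure `O=C(Nc1cccc(CNc2nccnc2Cl)c1)Nc1ccc(Cl)cc1Br`, gives 7480 nM in this assay, and compound 3, with structure `O=C(Nc1cccc(CNc2nccnc2Cl)c1)Nc1ccc(Cl)cc1Cl`, gives 6430 nM. The two measured changes away from compound 1 both replace the 4-methylphenyl on an amide-type nitrogen by a halogenated ring: a 1.6-fold lower number from compound 1 to compound 2 (0.20 log units; within the scatter) and a 1.9-fold lower number from compound 1 to compound 3 (0.27 log units; within the scatter). Between the two halogenated compounds, a 1.2-fold lower number from compound 2 to compound 3 (0.07 log units; within the scatter). For the measured compounds named here, all three steps fall within the usual scatter, so the numbers so far do not separate the compounds.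

Compound 4, with structure `CS(=O)(=O)c1ccc(NC(=O)Nc2cccc(CNc3nccnc3Cl)c2)cc1`, differs from compound 1 at the same ring: methylsulfonyl in place of methyl on an aromatic carbon, on an aromatic carbon of a six-membered aromatic ring of carbon only, para to a large group. No measured step swaps methyl for methylsulfonyl, so the steps shown bear only loosely on this change; they show that altering the substituents on that ring has so far moved the number by no more than the scatter. Compound 4 is therefore expected to give about 10000 nM in this assay, with a range from 3000 nM to 35000 nM. The expected step is a 1.2-fold lower number from compound 1 to compound 4 (0.08 log units; within the scatter), none beyond the scatter.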

Compound 4, half-maximal inhibitory concentration: 12300 nM
Compound 4: middle estimate off by 1.2-fold (0.09 log units), on the low side; the range from low to high includes it.
By their numbers in this assay, from the lowest: compounds 3, 2, 1 and 4 (each within the scatter of the next).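

Methylsulfonyl in place of methyl, on an aromatic carbon para to a large group, gives a 1.0-fold higher number from compound 1 to compound 4 (0.01 log units; within the scatter) in this assay. The earlier steps shown here put only halogens on this ring, whereas this change brings in a group of four heavy atoms in place of one, with two hydrogen-bond acceptors where methyl has none, and even so the number for compound 4 cannot be told apart from that for compound 1. No measurement at hand explains why so large a swap in atoms leaves the two compounds inseparable in this assay.

From the compounds shown here alone, the four compounds, taken in order of their numbers, each lie within the scatter of the next, so it remains open whether any substituent on this ring can shift the antiproliferative reading by more than the usual variation between repeats. Whether an amine, a carboxylic acid or a longer chain at this same carbon would give a number clearly apart from compound 1 stays unanswered, as does the effect of changes to the shared core rather than to this ring.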